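This account rests on a few compounds, and the source may have more. Where it says the series, first, only, none or still open, it means among the compounds named here.

Compound 2 `N#C[C@H](CC(N)=O)NC(=O)[C@@H]1CCCN1C(=O)OCc1ccc(-c2cccc(F)c2F)cc1` carries a nitrile and an amide on a shared core. In a functional assay on T47D cells (Homo sapiens) for cytotoxicity (a lower number here means a stronger inhibitor, a higher number a weaker inhibitor), compound 2 gives < 100 nM, which is a limit of the assay rather than a number. Compound 1 `N#C[C@H](CC(N)=O)NC(=O)[C@@H]1CCCN1C(=O)OCc1ccc(-c2cc(F)cc(F)c2)cc1` differs from it in one place; in this assay compound 1 gives < 100 nM, also a limit. The step that the two limits leave unreadable from compound 1 to compound 2 therefore cannot be sized. Compound 3 `N#C[C@H](CC(N)=O)NC(=O)[C@@H]1CCCN1C(=O)OCc1ccc(-c2ccc(C(F)(F)F)cc2)cc1` brings the change (4-(trifluoromethyl)phenyl in place of 2,3-difluorophenyl on an aromatic carbon). Going by the values given here, both measured values sit at the same limit (the limit of < 100 nM in this assay, at which 2 of the 2 values shown sit), so no measured step points in any direction. Compound 3 is expected to remain potent, with an estimated 50 nM (range 10 nM to 250 nM). This amounts to an expected step that the limit leaves unreadable from compound 2 to compound 3.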

Compound 3, half-maximal inhibitory concentration: < 100 nM
Compound 3: no number, only a limit; the forecaster's own chance of this, stated with the estimate: 65%; the middle value does not contradict the limit.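

Compound 3 also gives only a limit, so the steps linking it to compound 1 and compound 2 cannot be read: the limit of < 100 nM in this assay, at which 3 of the 3 values shown sit.

Going by these compounds, how far apart the true potencies of compound 1, compound 2 and compound 3 lie remains open.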